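This account rests on a few compounds, and the source may have more. Where it says the series, first, only, none or still open, it means among the compounds named here.

Measured in an ADME assay on MT4 cells (Homo sapiens) for cytotoxicity, read by MTT assay, with a stated time of 5 days; a lower number here means that less compound is tolerated, a higher number that more compound is tolerated:
compound 1 `CN(c1ccnc(Nc2ccc(C#N)cc2)n1)c1c(F)cc(-c2ccc(C#N)cc2)cc1F`: 148000 nM
compound 2 `CCN(c1ccnc(Nc2ccc(C#N)cc2)n1)c1c(F)cc(-c2ccc(C#N)cc2)cc1F`: 105000 nM
compound 3 `CC(C)CN(c1ccnc(Nc2ccc(C#N)cc2)n1)c1c(F)cc(-c2ccc(C#N)cc2)cc1F`: 241000 nM

Compound 3 holds the highest of the three numbers in this assay. Its gap to compound 1, a 1.6-fold higher number from compound 1 to compound 3 (0.21 log units; within the scatter), is within the scatter; its gap to compound 2, a 2.3-fold higher number from compound 2 to compound 3 (0.36 log units; beyond the scatter), is beyond it, though modest. The step of a 1.4-fold lower number from compound 1 to compound 2 (0.15 log units; within the scatter) is within the scatter.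

Compound 4 `N#Cc1ccc(Nc2nccc(N(CC3CCCC3)c3c(F)cc(-c4ccc(C#N)cc4)cc3F)n2)cc1` differs from compound 3 by cyclopentyl in place of isopropyl on a saturated chain carbon bound to a nitrogen on an aromatic ring. Going by the values given here, the steps that bear on this are the enlargements on the same carbon, a 1.6-fold higher number from compound 1 to compound 3 (0.21 log units; within the scatter) and a 2.3-fold higher number from compound 2 to compound 3 (0.36 log units; beyond the scatter); the growth of this group has so far moved the number in this assay by little, at most modestly upward. For compound 4 no step beyond the scatter is therefore expected, a 1.1-fold higher number from compound 3 to compound 4 (0.03 log units; within the scatter), giving an estimate of 260000 nM with a range of 130000 nM to 520000 nM.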

Compound 4, half-maximal cytotoxic concentration: > 247000 nM
Compound 4 was reported as a limit; the forecaster's own chance of this, stated with the estimate: 10%; the middle value lies beyond the limit too.
By their numbers in this assay, from the lowest: compounds 2, 1 and 3 (each within the scatter of the next, the first and the last beyond it). At a limit, above all of these: compound 4.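

Compound 4, with cyclopentyl on this saturated chain carbon bound to a nitrogen on an aromatic ring, gives no number in this assay, only a limit: the limit of > 247000 nM in this assay, at which 1 of the 4 values shown sits.

The floor of an at least 2.3-fold higher number from compound 2 to compound 4 (0.37 log units; beyond the scatter) clears the scatter, while those of an at least 1.0-fold higher number from compound 3 to compound 4 (0.01 log units; that floor lies within the scatter) and an at least 1.6-fold higher number from compound 1 to compound 4 (0.22 log units; that floor lies within the scatter) do not. A ring at this place therefore brings no fall in the number, which the open chains could not show.

From the compounds shown here alone, how far compound 4 lies past its limit stays open. So does whether an amine or a carboxylic acid at this place would keep the number this high.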